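Two Stereocentres Reversed on a Shared Core

The compounds below may be only part of what the source reports. "The series", "measured", "known", "first", "only" and "open" are said of these compounds alone.

Of the compounds shown here, three built on one shared core have been tested for their ability to kill cultured cancer cells. In a functional assay on HeLa cells (Homo sapiens) for cytotoxicity, read by WST assay, with a stated time of 48 h (a higher number here means a weaker inhibitor, a lower number a stronger inhibitor), compound 2, `COc1ccc(CCC[C@H]2C[C@@H]([C@@H](O)c3ccc(OC)c(OC)c3)CO[C@@H]2c2ccc(OC)c(OC)c2)cc1OC`, gives 37700 nM. Compound 3, `COc1ccc(/C=C/C[C@H]2C[C@H]([C@H](O)c3ccc(OC)c(OC)c3)CO[C@@H]2c2ccc(OC)c(OC)c2)cc1OC`, gives 34600 nM in this assay, and the two numbers sit within the scatter of each other, so neither compound can be placed ahead of the other. Compound 1, `COc1ccc(/C=C/C[C@H]2C[C@@H]([C@@H](OC(C)=O)c3ccc(OC)c(OC)c3)CO[C@@H]2c2ccc(OC)c(OC)c2)cc1OC`, returns no number but only a limit of this assay, > 100000 nM. That value is the limit of > 100000 nM in this assay, at which 1 of the 3 values shown sits.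

Among the compounds with values here, compound 4, `COc1ccc(/C=C/C[C@H]2C[C@@H]([C@@H](O)c3ccc(OC)c(OC)c3)CO[C@@H]2c2ccc(OC)c(OC)c2)cc1OC`, has not yet been measured. the two compounds have the same atoms and bonds and differ only in configuration as drawn: 2 of 5 stereo elements differ; a stereocentre at a saturated ring carbon is drawn S in compound 3 and R in compound 4; a stereocentre at a saturated chain carbon is drawn S in compound 3 and R in compound 4 Among the three measured compounds no pair differs in a single place, so no measured step gives the size of such a change in configuration, and the data offer no guide to which direction it might take.

The expectation is therefore a cautious one: the step of a 1.0-fold higher number from compound 3 to compound 4 (0.00 log units; within the scatter) is expected to stay within the usual scatter, with no change beyond it in either direction. Compound 4 is estimated to give 35000 nM in this assay, with a plausible range from 12000 nM to 100000 nM.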

Compound 4, half-maximal inhibitory concentration: 23800 nM
The estimate for compound 4 lay 1.5-fold (0.17 log units) above the measured number; measured number inside the range.
By their numbers in this assay, from the lowest: compounds 4, 3 and 2 (each within the scatter of the next). At a limit, above all of these: compound 1.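

In this assay, reversing the two stereocentres gives a 1.5-fold lower number from compound 3 to compound 4 (0.16 log units; within the scatter), so for this pair the drawn configuration at the saturated ring carbon and the saturated chain carbon, taken together, shifts the number by no more than the scatter, and the comparison is a clean one: the fact that compounds 3 and 4 differ only in the configuration as drawn Placing 2-(3,4-dimethoxyphenyl)ethenyl in place of 2-(3,4-dimethoxyphenyl)ethyl on the saturated chain carbon gives a 1.6-fold lower number from compound 2 to compound 4 (0.20 log units; within the scatter), so this change in the chain does not separate the two compounds either. Hydrogen in place of acetyl on the oxygen on a saturated carbon gives an at least 4.2-fold lower number from compound 1 to compound 4 (0.62 log units; beyond the scatter), the one step here beyond the scatter, and its true size stays unknown because compound 1 stands at a limit rather than a number: the limit of > 100000 nM in this assay, at which 1 of the 4 values shown sits.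

From the compounds shown here alone, the two stereocentres change together here, so what each one does alone remains open. Also open, going by these compounds, is whether the free hydroxyl itself matters or only the loss of the acetyl, a question that an amine on that saturated carbon, or a longer chain on that oxygen than acetyl, could help to settle.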